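A Long Chain Made Unsaturated in an Amide Antagonist

A few compounds are considered here, and "the series" means these few. Any claim that something is new, unique, unknown or untested is made for them only; others in the source may bear on it.

Compound 1, `CCCCCCCCCCCCCCCCSCCC(=O)NCc1ccc(O)c(OC)c1`, is measured in an assay on HEK293 cells for antagonist activity at transient receptor potential cation channel subfamily V member 2 (Rattus norvegicus), read by fluorescence and calcium flux, with a stated time of 5 min (on this read-out lower numbers stand for stronger inhibition and higher numbers for weaker inhibition), where it gives 3800 nM. Of the two numbers obtained so far, this is the higher one. The nearest number belongs to compound 3, `CCCCCCCCCCCCCCCCSC[C@H](N)C(=O)NCc1ccc(O)c(OC)c1`, which gives 1400 nM in this assay. For the measured compounds named here, the single measured step runs a 2.7-fold lower number from compound 1 to compound 3 (0.43 log units; beyond the scatter). A third compound, compound 2, `CCCCCCCCCCCCCCCCCCCC(N)=O`, reaches only the limit of this assay, > 10000 nM, so no number is known for it (the limit of > 10000 nM in this assay, at which 1 of the 3 values shown sits).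

Compound 4, `CCCCC/C=C\C/C=C\CCCCCCCCSCCC(=O)NCc1ccc(O)c(OC)c1`, is not yet measured. It differs from compound 1 by deca-1,4-dien-1-yl in place of octyl on a saturated chain carbon, eight bonds along the chain from a sulfur. This change sits far along the long chain, away from the amide and the aromatic core shared by compound 1, compound 3 and compound 4. Going by the values given here, no measured step touches that part of the chain: the only step, from compound 1 to compound 3, alters the carbon bound to the carbonyl, and compound 2 lacks the core altogether. Among the compounds with values here, the change to compound 4 therefore has no direct precedent here, and the expectation is a step of no more than the usual scatter, in either direction.

Accordingly compound 4 is expected to give 3000 nM in this assay, most likely between 1000 nM and 9000 nM, which is an expected step of a 1.3-fold lower number from compound 1 to compound 4 (0.10 log units; within the scatter).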

Compound 4, half-maximal inhibitory concentration: 1400 nM
Beside the measured number, compound 4's estimate is 2.1-fold (0.33 log units) above it; low and high end bracket the measured number.
By their numbers in this assay, from the lowest: compounds 3 and 4 (each within the scatter of the next); then compound 1. At a limit, above all of these: compound 2.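

In this assay, for the compounds shown here, putting deca-1,4-dien-1-yl in place of octyl, eight bonds along the chain from a sulfur, gives a 2.7-fold lower number from compound 1 to compound 4 (0.43 log units; beyond the scatter) and so shows that this far part of the chain, which no earlier step touched, does bear on the read-out. The step is modest, yet it is a second change that lowers the number from compound 1, after a 2.7-fold lower number from compound 1 to compound 3 (0.43 log units; beyond the scatter) on the saturated chain carbon bound to a carbonyl carbon. Nothing measured here accounts for the size of this new step.

The entering group brings both extra carbons and two double bonds, so the compounds shown do not separate these two features: that would take a saturated decyl group, or a chain with a single double bond, in place of octyl. Also open, going by these compounds, is whether the amino group of compound 3 and the deca-1,4-dien-1-yl group of compound 4 would add up when combined in one compound, and how a still longer unsaturated chain would behave.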